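Ethyl to propyl on the aryl ether of compound 3

The source may hold more compounds than are shown below. What is called first, only, known or untested is meant among the compounds shown, and "the series" means these compounds.

Measured compounds:
compound 1 `C/C=C(\CC)Oc1cc(C)nc(Oc2c(C)cc(C)cc2C)c1C` with 75%
compound 2 `CCC(CC)Oc1cc(C)nc(Oc2c(C)cc(C)cc2C)c1[N+](=O)[O-]` with 59%
compound 3 `CCc1cc(C)c(Oc2nc(C)cc(OC(CC)CC)c2C)c(C)c1` with 55%

In a functional assay on the whole organism for displacement of a labelled ligand, with Rattus norvegicus as the target, at a dose of 3.2 mg/kg by the subcutaneous route (a lower number here means less inhibition, a higher number more inhibition at the dose given (going by the name of the read-out)), compound 1 gives 75%, compound 2 gives 59% and compound 3 gives 55%. Compound 3 carries the smallest of the three numbers. Its number and that of compound 2 lie within the scatter of each other, so no order between them can be read. Its number stands beyond the scatter under that of compound 1, the only difference in this assay among these three that counts as real. No pair of these compounds differs in a single place, so no step can be assigned to one structural change.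

Compound 4 `CCCc1cc(C)c(Oc2nc(C)cc(OC(CC)CC)c2C)c(C)c1` has not yet been measured in this assay. It differs from compound 3 by methyl in place of hydrogen on a saturated chain carbon, two bonds along the chain from an aromatic carbon. Among the measured compounds shown here, nothing among the measured compounds isolates a change of this kind, so the expectation rests on compound 3 alone and on the smallness of the change. From compound 3 the expected step is no change at the digits printed from compound 3 to compound 4 (within the scatter), none beyond the scatter. Compound 4 is estimated to give 55%, with a range from 35% to 75%.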

Compound 4, a percentage reported as inhibition, in the whole organism at one dose (the size of the read-out at that dose, not a potency): 42%
Compound 4: middle estimate off by 13 percentage points, on the high side; the measured number falls inside the stated range.
By their numbers in this assay, from the lowest: compound 4; then compounds 3 and 2 (each within the scatter of the next); then compound 1.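

In this assay, the series now has its first step tied to one structural change: methyl in place of hydrogen on a saturated chain carbon, two bonds along the chain from an aromatic carbon, gives a number 13 percentage points lower from compound 3 to compound 4 (beyond the scatter) and so counts as a modest but real difference. Among the compounds shown here, this position therefore responds to a change as small as ethyl to propyl, which the earlier compounds, none differing from another in one place, could not show. Nothing measured here accounts for the step.

As far as these compounds go, whether a longer chain such as butyl, a branched chain such as isopropyl, or a chain ending in an amine would take the number further down remains open. Also open, from the compounds shown here alone, is whether ethyl to propyl gives a step of similar size on the cores of compound 1 and compound 2.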